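The source may report more compounds than this note shows. Statements on the series, on what has been measured and on what is new or still open speak of the compounds shown alone.

Measured so far in a functional assay on Vas deferens for antagonist activity at Alpha-1A adrenergic receptor (Rattus norvegicus); on this read-out higher numbers stand for higher potency (the scale is a negative logarithm) and lower numbers for lower potency:
compound 1, `COc1ccccc1N1CCN(CC2Nc3ccccc3S(=O)(=O)N2)CC1` — 5.81
compound 2, `COc1ccccc1N1CCN(CC2Nc3cc(C)ccc3S(=O)(=O)N2)CC1` — 6

Compound 2 holds the higher of the two figures, though the step of a number 0.19 log units higher from compound 1 to compound 2 (within the scatter) lies within the scatter. Compound 3, `COc1ccccc1N1CCN(CC2Nc3cc(Cl)ccc3S(=O)(=O)N2)CC1`, carries chloro in place of methyl on an aromatic carbon. Among the compounds with values here, the only measured step, from compound 1 to compound 2, concerns a different exchange and stayed within the scatter; no measured pair bears directly on swapping methyl for chloro. The expected step is therefore small, a number 0.10 log units higher from compound 2 to compound 3 (within the scatter), with no change beyond the scatter. For compound 3 the estimate in this assay is 6.1, ranging from 5.6 to 6.6.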

Compound 3, negative logarithm of the antagonist equilibrium constant: 5.05
Beside the measured number, compound 3's estimate is 1.05 log units above it; measured number below the stated range.
By their numbers in this assay, from the lowest: compound 3; then compounds 1 and 2 (each within the scatter of the next).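

At this position on the aromatic ring, the group present matters in this assay: chloro in place of methyl gives a clear loss (a number 0.95 log units lower from compound 2 to compound 3 (beyond the scatter)), and chloro in place of hydrogen does too (a number 0.76 log units lower from compound 1 to compound 3 (beyond the scatter)). Methyl and hydrogen had not been separated beyond the scatter, so chloro is the first group here to move the potency beyond it. No evidence is available that accounts for this loss.

On these data alone, whether the loss is particular to chloro stays open, as fluoro, methoxy or an amine at this position could give a different result.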